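Dithiocarbamate series on breast cancer cells: a heteroaryl swap

The source may hold more compounds than are shown below. What is called first, only, known or untested is meant among the compounds shown, and "the series" means these compounds.

Compound 1, `OCCCSC(=S)NCc1cccnc1`: 6610 nM
Compound 2, `S=C(NCc1cccnc1)SCCc1noc(-c2ccccc2)n1`: 10100 nM
Compound 3, `Fc1ccccc1-c1nnc(CCSC(=S)NCc2cccnc2)o1`: 3420 nM

In a functional assay on MDA-MB-468 cells (Homo sapiens) for cytotoxicity, read by resazurin assay, with a stated time of 72 h (on this read-out higher numbers stand for weaker inhibition and lower numbers for stronger inhibition), compound 3 gives 3420 nM, the lowest of the three numbers. Its gap to compound 1 lies within the scatter, so no order between these two can be claimed; its gap to compound 2 lies beyond the scatter, and compound 2 gives the highest number of the set.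

The step to compound 4, `S=C(NCc1cccnc1)SCCc1nnc(-c2cc3ccccc3s2)o1`, changes one group: 1-benzothiophen-2-yl in place of 2-fluorophenyl on an aromatic carbon. Going by the values given here, no measured pair shows what such a swap does on this core, so the expectation rests on compound 3 alone. A step of a 1.0-fold higher number from compound 3 to compound 4 (0.01 log units; within the scatter) is expected, within the scatter, with no direction to favour. Compound 4 is therefore estimated at 3500 nM, in the range 1200 nM to 10000 nM.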

Compound 4, half-maximal inhibitory concentration: 6770 nM
Compound 4: the middle estimate sits 1.9-fold (0.29 log units) below what was measured; the measured number falls inside the stated range.
By their numbers in this assay, from the lowest: compounds 3, 1, 4 and 2 (each within the scatter of the next, the first and the last beyond it).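

In this assay, going by these compounds alone, putting 1-benzothiophen-2-yl in place of 2-fluorophenyl gives a 2.0-fold higher number from compound 3 to compound 4 (0.30 log units; within the scatter), the only step here that isolates a change in one place. On this aromatic carbon, then, a fused two-ring group and a single fluorinated ring cannot be told apart, so no order can be claimed between these two compounds. Nothing available explains this result.

As far as these compounds go, what a basic amine such as a morpholine or a carboxylic acid would do on this carbon stays open. So does whether a plain phenyl or a small methyl group would give a step beyond the scatter.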